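Methyl on a Ring Nitrogen: An Unmeasured Step

This account rests on a few compounds, and the source may have more. Where it says the series, first, only, none or still open, it means among the compounds named here.

Compound 2 `O=C(Nc1ccc(Oc2ccnc3[nH]ccc23)cc1)c1cc2cccnc2n(-c2ccc(Br)cc2)c1=O` gives 270 nM in a functional assay on HT-29 cells (Homo sapiens) for antiproliferative activity, read by MTT assay, with a stated time of 72 h (a lower number here means a stronger inhibitor, a higher number a weaker inhibitor), the lowest of the three numbers gathered so far. Compound 1 `O=C(Nc1ccc(Oc2ccnc3[nH]ccc23)cc1)c1cc2cccnc2n(-c2ccc(Cl)cc2)c1=O` gives 280 nM, so there is a 1.0-fold lower number from compound 1 to compound 2 (0.02 log units; within the scatter). Compound 3 `O=C(Nc1ccc(Oc2ccnc3[nH]ccc23)cc1)c1cc2cccnc2n(-c2ccc(Br)cc2F)c1=O` gives 2360 nM; there is an 8.7-fold higher number from compound 2 to compound 3 (0.94 log units; beyond the scatter), and likewise an 8.4-fold higher number from compound 1 to compound 3 (0.93 log units; beyond the scatter). Compound 4 `Cn1ccc2c(Oc3ccc(NC(=O)c4cc5cccnc5n(-c5ccc(Br)cc5)c4=O)cc3)ccnc21` differs from compound 2 by methyl in place of hydrogen on an aromatic nitrogen. Neither measured step touches this part of the shared core; both concern the halogenated phenyl group, so nothing here shows how this place responds to change. For the measured compounds named here, with no bearing step, a step of a 2.2-fold higher number from compound 2 to compound 4 (0.35 log units; beyond the scatter) is expected, stated with a wide range. Compound 4 is estimated at 600 nM, expected to fall between 150 nM and 3000 nM.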

Compound 4, half-maximal inhibitory concentration: 690 nM
The estimate for compound 4 lay 1.2-fold (0.06 log units) below the measured number, and the stated range covers the measured number.
By their numbers in this assay, from the lowest: compounds 2 and 1 (each within the scatter of the next); then compound 4; then compound 3.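

For the compounds shown here, until now, only the halogenated phenyl group had changed, so this is the first reading of how the aromatic nitrogen of the five-membered ring responds to change. In this assay, methyl in place of the hydrogen on that nitrogen gives a 2.6-fold higher number from compound 2 to compound 4 (0.41 log units; beyond the scatter), a modest weakening rather than a complete loss of activity. Nothing available explains this weakening. From the compounds shown here alone, it remains open how a longer chain such as ethyl, or a chain ending in an amine, would fare on this nitrogen. Whether methyl would have the same effect on compound 1 is also unknown.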